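Stereochemical flip in a triazole series against alpha-mannosidase

The source may report more compounds than this note shows. Statements on the series, on what has been measured and on what is new or still open speak of the compounds shown alone.

Working notes on a small set of polyhydroxylated pyrrolidines tested in an assay on isolated protein for inhibition of alpha-mannosidase (Canavalia ensiformis), with stated times of 5 min and 20 min, tested at 1 mM; a lower number here means less inhibition, a higher number more inhibition at the concentration tested (going by the name of the read-out). Compound 1 `O[C@@H]1[C@H](O)CN[C@H]1CNC(=S)Nc1ccccc1` carries a thiourea arm and in this assay compound 1 is reported as "not active" (no number reported), with no number given. Compound 2 `O[C@@H]1[C@@H](c2cn(Cc3ccccc3)nn2)NC[C@@H]1O` bears a benzyl-substituted triazole directly on the ring and in this assay compound 2 gives 30%. Compound 3 `O[C@H]1[C@@H](O)CN[C@@H]1Cn1cc(-c2ccccc2)nn1` has a phenyl-substituted triazole linked through a methylene and in this assay compound 3 gives 60%. On the numbers shown, compound 2 stands lowest of the two reported values; its nearest neighbour is compound 3, whose number lies higher by a gap beyond the usual scatter, while compound 1 stands apart without a single number.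

The open question concerns compound 4 `O[C@@H]1[C@H](O)CN[C@@H]1c1cn(Cc2ccccc2)nn1`. Relative to compound 2 the change is the two compounds have the same atoms and bonds and differ only in configuration as drawn: 2 of 3 stereo elements differ; a stereocentre at a saturated ring carbon is drawn R in compound 2 and S in compound 4; a stereocentre at a saturated ring carbon is drawn S in compound 2 and R in compound 4. Within the data shown here, no measured pair in the set differs only in configuration, so there is no comparable step to lean on; the direction is not predictable from the data, and a step either way, or none beyond the scatter, is possible.

For compound 4 the value in this assay is expected to lie around 30%, within 5% to 65%. The expected step of no change at the digits printed from compound 2 to compound 4 (within the scatter) is therefore estimated as essentially flat.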

Compound 4, a percentage reported as inhibition, at one concentration (the size of the read-out at that concentration, not a potency): "not active" (no number reported)
Compound 4 has no reported number here; there is nothing to compare the estimate with.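

In this assay, among these compounds, compound 4 gives "not active" (no number reported), so no step from compound 2, at 30%, can be read. Left open is how far configuration alone moves inhibition in this assay, and the comparison rests on a single structural point: the fact that compounds 2 and 4 differ only in the configuration as drawn.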